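Methyl to Ethyl on the Shared Core

This account rests on a few compounds, and the source may have more. Where it says the series, first, only, none or still open, it means among the compounds named here.

Measured so far in a functional assay on U2OS cells for antagonist activity at C-X-C chemokine receptor type 3 (Homo sapiens), read by beta-arrestin recruitment; a lower number here means a stronger inhibitor, a higher number a weaker inhibitor:
Compound 1, `Cc1nc(C)n(CC(=O)N2CCN(c3sc(C(F)(F)F)nc3-c3cnc(OC4CCC4)nc3)C[C@H]2C)n1`: in this assay compound 1 gives 78 nM
Compound 2, `Cc1ncc(-c2nc(C(F)(F)F)sc2N2CCN(C(=O)Cn3nc(C)nc3C)[C@H](C)C2)cn1`: in this assay compound 2 gives 578 nM

Among the compounds with values here, compound 2 holds the higher of the two numbers; its nearest neighbour is compound 1, and the only measured step between them, a 7.4-fold higher number from compound 1 to compound 2 (0.87 log units; beyond the scatter), replaced cyclobutyloxy by methyl on an aromatic carbon and lost potency well beyond the scatter.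

Compound 3, `CCc1ncc(-c2nc(C(F)(F)F)sc2N2CCN(C(=O)Cn3nc(C)nc3C)[C@H](C)C2)cn1`, differs from compound 2 by methyl in place of hydrogen on a saturated chain carbon bound to an aromatic carbon; read one bond further out, the change is methyl to ethyl, 2-methylpyrimidin-5-yl to 2-ethylpyrimidin-5-yl. Within the data shown here, only the step from compound 1 to compound 2 bears on it, and that step ran the other way, from a larger group to methyl. Adding a single carbon goes back a short way toward the larger substituent, so a small gain is expected for compound 3, though one that may not clear the scatter, giving an expected step of a 1.5-fold lower number from compound 2 to compound 3 (0.18 log units; within the scatter). Compound 3 is therefore estimated at 380 nM, with a range of 150 nM to 1000 nM.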

Compound 3, half-maximal inhibitory concentration: 1430 nM
Compound 3: the middle estimate sits 3.8-fold (0.58 log units) below what was measured; measured number outside the range, above it.
By their numbers in this assay, from the lowest: compound 1; then compound 2; then compound 3.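

In this assay the change from 2-methylpyrimidin-5-yl to 2-ethylpyrimidin-5-yl produced a 2.5-fold higher number from compound 2 to compound 3 (0.39 log units; beyond the scatter) and so showed that this position responds to a single added carbon, with the number moving up rather than down. Set against cyclobutyloxy, the ethyl group gave an 18-fold higher number from compound 1 to compound 3 (1.26 log units; beyond the scatter) and this is a wider gap than methyl left, so the number of heavy atoms in the group does not by itself order the three compounds, with ethyl going against any reading in which a larger group gives a lower number. Nothing shown here accounts for this behaviour at the position.

Still open, going by these compounds, is whether the lower number of compound 1 goes with the oxygen that links its group to the aromatic carbon, with the ring, or with both together, as cyclobutyloxy differs from methyl and ethyl in both respects. A methoxy or ethoxy group would test the oxygen link, while a cyclobutyl group bound directly to the aromatic carbon would test the ring, and a longer chain such as propyl would show whether the upward move seen with ethyl continues.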